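The source may report more compounds than this note shows. Statements on the series, on what has been measured and on what is new or still open speak of the compounds shown alone.

Values in a functional assay on HeLa cells (Homo sapiens) for antiproliferative activity, read by MTT assay, with a stated time of 48 h; on this read-out higher numbers stand for weaker inhibition and lower numbers for stronger inhibition:
- compound 1 `O=[N+]([O-])c1cccc(-c2nn(-c3ccccc3)cc2C(Nc2nc3ccccc3s2)c2c(O)ccc3ccccc23)c1`: 8220 nM
- compound 2 `Cc1cccc(-c2nn(-c3ccccc3)cc2C(Nc2nc3ccccc3s2)c2c(O)ccc3ccccc23)c1`: 7020 nM
- compound 3 `Oc1ccc2ccccc2c1C(Nc1nc2ccccc2s1)c1cn(-c2ccccc2)nc1-c1cccc(Cl)c1`: 6830 nM

Compound 1 has the highest of these numbers, yet all three values lie within the scatter of each other. Compound 4 `O=[N+]([O-])c1cccc(-c2nn(-c3ccccc3)cc2C(Nc2nc3ccc(Cl)cc3s2)c2c(O)ccc3ccccc23)c1` differs from it by chloro in place of hydrogen on an aromatic carbon, turning 1,3-benzothiazol-2-yl into 6-chloro-1,3-benzothiazol-2-yl. The measured steps, a 1.2-fold lower number from compound 1 to compound 2 (0.07 log units; within the scatter), a 1.2-fold lower number from compound 1 to compound 3 (0.08 log units; within the scatter) and a 1.0-fold lower number from compound 2 to compound 3 (0.01 log units; within the scatter), are all small, but each changes another place, so none tests this one directly. The step expected here in this assay is a 1.3-fold lower number from compound 1 to compound 4 (0.10 log units; within the scatter), none beyond the scatter. For compound 4 the estimated value is 6500 nM, with an expected range of 3000 nM to 13000 nM.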

Compound 4, half-maximal inhibitory concentration: 15500 nM
The estimate for compound 4 lay 2.4-fold (0.38 log units) below the measured number; the whole stated range lies below it.
By their numbers in this assay, from the lowest: compounds 3, 2, 1 and 4 (each within the scatter of the next, the first and the last beyond it).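

Chloro on the 1,3-benzothiazol-2-yl group, giving 6-chloro-1,3-benzothiazol-2-yl, is the first change shown at this end of the molecule; the earlier steps all changed another place. In this assay, a 1.9-fold higher number from compound 1 to compound 4 (0.28 log units; within the scatter) stays inside the usual scatter, so this place accepts chloro with no change that can be read. No evidence on the cause of this result is at hand.

Open, going by these compounds, is whether an amine or a carboxylic acid at this place would also stay within the scatter of compound 1. Also open, on these data alone, is whether chloro here reads the same with the methyl group of compound 2.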